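Sulfonamide substituent change in the cytotoxicity series

This account rests on a few compounds, and the source may have more. Where it says the series, first, only, none or still open, it means among the compounds named here.

Compound 2 `CCS(=O)(=O)Nc1ccc(NC(=O)c2ccc(Cl)c([N+](=O)[O-])c2)cc1F` gives 83700 nM in an ADME assay on HEK293 cells (Homo sapiens) for cytotoxicity, read by MTT assay, with a stated time of 48 h (on this read-out lower numbers stand for stronger inhibition and higher numbers for weaker inhibition), the higher of the two numbers, with compound 1 `CS(=O)(=O)Nc1ccc(NC(=O)c2ccc(Cl)c([N+](=O)[O-])c2)cc1F` at 23100 nM. Compound 3 `O=C(Nc1ccc(NS(=O)(=O)C(F)(F)F)c(F)c1)c1ccc(Cl)c([N+](=O)[O-])c1` carries trifluoromethyl in place of ethyl on a sulfonyl sulfur. Among the compounds with values here, the only measured step, a 3.6-fold higher number from compound 1 to compound 2 (0.56 log units; beyond the scatter), concerns a different change on the same sulfonyl sulfur and raised the number; no step covers the present change. For compound 3 the expected number is therefore close to compound 2, as a 1.4-fold lower number from compound 2 to compound 3 (0.14 log units; within the scatter), with wide uncertainty: estimate 60000 nM, ranging from 20000 nM to 180000 nM.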

Compound 3, half-maximal inhibitory concentration: 194000 nM
Compound 3: the middle estimate sits 3.2-fold (0.51 log units) below what was measured; measured number outside the range, above it.
By their numbers in this assay, from the lowest: compound 1; then compound 2; then compound 3.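

On the sulfonyl sulfur, trifluoromethyl gives a higher number in this assay than ethyl (a 2.3-fold higher number from compound 2 to compound 3 (0.37 log units; beyond the scatter)) and methyl (an 8.4-fold higher number from compound 1 to compound 3 (0.92 log units; beyond the scatter)). The number at this position therefore changes with fluorine on the group as well as with the methyl-to-ethyl extension, and compound 3 stands highest of the three. Nothing available explains this order.

Going by these compounds, whether a longer chain such as propyl continues the rise remains open. So does whether difluoromethyl or a phenyl group on the same sulfur gives a number within this range.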